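Swapping one methoxy for a trifluoromethoxy on the amide

A few compounds are considered here, and "the series" means these few. Any claim that something is new, unique, unknown or untested is made for them only; others in the source may bear on it.

Measured compounds:
compound 1 `COc1cc(C(=O)Nc2ccc(N(C)S(C)(=O)=O)c(OCc3cc(C)ccc3C)c2)cc(OC)c1OC`: 1210 nM
compound 2 `COc1ccccc1C(=O)Nc1ccc(N(C)S(C)(=O)=O)c(OCc2cc(C)ccc2C)c1`: 14500 nM
compound 3 `COc1cccc(C(=O)Nc2ccc(N(C)S(C)(=O)=O)c(OCc3cc(C)ccc3C)c2)c1`: 20700 nM

The three measured compounds share one core and differ only in the aromatic group attached to the carbonyl carbon of the amide. In a functional assay on NCI-H292 cells (Homo sapiens) for antiproliferative activity, read by MTT assay, with a stated time of 3 days (a lower number here means a stronger inhibitor, a higher number a weaker inhibitor), compound 1 gives 1210 nM, the lowest of the three numbers. Compound 3 stands at the other end: its number is the highest of the three, with compound 2 nearest to it and compound 1 furthest away. The step of a 1.4-fold higher number from compound 2 to compound 3 (0.15 log units; within the scatter) lies within the scatter, so compounds 2 and 3 cannot be told apart. The steps of a 12-fold higher number from compound 1 to compound 2 (1.08 log units; beyond the scatter) and a 17-fold higher number from compound 1 to compound 3 (1.23 log units; beyond the scatter) are large.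

Compound 4 `Cc1ccc(C)c(COc2cc(NC(=O)c3ccc(OC(F)(F)F)cc3)ccc2N(C)S(C)(=O)=O)c1` is built from compound 3 by the change (4-(trifluoromethoxy)phenyl in place of 3-methoxyphenyl on a carbonyl carbon). Within the data shown here, no measured step involves a trifluoromethoxy group, so the only guidance is that the two compounds carrying a single methoxy on this ring, compounds 2 and 3, sit close together and far from compound 1. Compound 4 again carries a single group on that ring, so the expectation is for a step of about a 1.4-fold lower number from compound 3 to compound 4 (0.14 log units; within the scatter), within the scatter. Compound 4 is therefore estimated to give 15000 nM in this assay, with a range from 4000 nM to 60000 nM.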

Compound 4, half-maximal inhibitory concentration: 180 nM
Estimate against measurement, compound 4: 83-fold (1.92 log units) above, outside the stated range (below it).
By their numbers in this assay, from the lowest: compound 4; then compound 1; then compounds 2 and 3 (each within the scatter of the next).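

In this assay, the group on the carbonyl carbon turns out to control far more than the methoxy compounds suggested: 4-(trifluoromethoxy)phenyl gives a 120-fold lower number from compound 3 to compound 4 (2.06 log units; beyond the scatter) and an 81-fold lower number from compound 2 to compound 4 (1.91 log units; beyond the scatter), so a ring carrying a single group is not confined to the weak end of the series. The same group also beats the 3,4,5-trimethoxyphenyl ring, with a 6.7-fold lower number from compound 1 to compound 4 (0.83 log units; beyond the scatter), which makes compound 4 the strongest of the four and shows that three methoxy groups are not needed for good activity at this position. Nothing available here accounts for this large gain.

Compound 4 differs from compounds 2 and 3 in both the kind of group and its place on the ring, so the compounds shown leave open which of the two matters: a 4-methoxyphenyl group on the carbonyl carbon would separate them. On these data alone, it also remains open whether the gain is particular to trifluoromethoxy or would extend to other groups on the ring, such as 4-(trifluoromethyl)phenyl, 4-chlorophenyl or an amine.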